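Returning to a six-membered ring on the piperidine amine

The compounds below may be only part of what the source reports. "The series", "measured", "known", "first", "only" and "open" are said of these compounds alone.

Of the compounds shown here, two sharing one core have been measured. Compound 1 `Cc1cc(C)c(S(=O)(=O)N2CCC(N3CCC(C)CC3)CC2)c(C)c1` carries a 4-methylpiperidin-1-yl group, and in a functional assay on DLD-1 cells (Homo sapiens) for antiproliferative activity, read by CellTiter-Glo, with a stated time of 72 h (on this read-out higher numbers stand for weaker inhibition and lower numbers for stronger inhibition), compound 1 gives 0.03 nM. For the measured compounds named here, compound 2 `Cc1cc(C)c(S(=O)(=O)N2CCC(N3CCCCCC3)CC2)c(C)c1` carries an azepan-1-yl group in its place, and in this assay compound 2 gives 5.3 nM, the highest of the two numbers seen so far; the single measured step, a 180-fold higher number from compound 1 to compound 2 (2.25 log units; beyond the scatter), separates them. Compound 3 `Cc1cc(C)c(S(=O)(=O)N2CCC(N3CC(C)CC(C)C3)CC2)c(C)c1` has not been measured. It differs from compound 2 in one place: 3,5-dimethylpiperidin-1-yl in place of azepan-1-yl on a saturated ring carbon. Going by the values given here, the only step that bears on this change is the one from compound 1 to compound 2, which was large, and it moved from a six-membered ring to a seven-membered one; compound 3 moves back to a six-membered ring, now bearing two methyl groups. The number for compound 3 is therefore expected to fall well below that of compound 2, by an 18-fold lower number from compound 2 to compound 3 (1.25 log units; beyond the scatter), although a methyl pattern unlike that of compound 1 leaves the exact size uncertain. Compound 3 is estimated at 0.3 nM, within a range of 0.03 nM to 3 nM.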

Compound 3, half-maximal inhibitory concentration: 17 nM
For compound 3 the middle estimate is 57-fold (1.75 log units) below the measured one; measured number above the stated range.
By their numbers in this assay, from the lowest: compound 1; then compound 2; then compound 3.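

In this assay, a six-membered ring on this saturated ring carbon does not by itself give a low number: 3,5-dimethylpiperidin-1-yl in place of azepan-1-yl gives a 3.2-fold higher number from compound 2 to compound 3 (0.51 log units; beyond the scatter). Compounds 1 and 3 both carry a six-membered ring and differ in their methyl groups, yet the change gives a 570-fold higher number from compound 1 to compound 3 (2.75 log units; beyond the scatter), so the methyl pattern on that ring matters at least as much as ring size in these compounds. Nothing available explains this difference.

The compounds shown leave open how the unsubstituted piperidin-1-yl group would compare, and so whether the 4-methyl group lowers the number or the 3,5-dimethyl pattern raises it. A 3-methylpiperidin-1-yl or 4-ethylpiperidin-1-yl group would also test how narrow this preference is.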